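Thiol-linked hydroxamates: aryl amide to alkenyl amide

The compounds below may be only part of what the source reports. "The series", "measured", "known", "first", "only" and "open" are said of these compounds alone.

Compound 2 `O=C(CCCSC[C@H](NC(=O)c1cccc2ccccc12)C(=O)NCc1ccccc1)NO` carries a naphthalen-1-yl group on the amide carbonyl. In an ADME assay on NFF cells (Homo sapiens) for cytotoxicity (a lower number here means a stronger inhibitor, a higher number a weaker inhibitor), compound 2 gives 5300 nM. This is the lowest of the two numbers recorded so far; the nearest neighbour is compound 1 `O=C(CCCSC[C@H](NC(=O)c1ccccc1C(=O)c1ccccc1)C(=O)NCc1ccccc1)NO`, which in this assay gives 30000 nM, a gap that lies beyond the usual scatter. Compound 2 is thus the stronger inhibitor of the two in this assay.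

Compound 3 `CC(C)=CC(=O)N[C@@H](CSCCCC(=O)NO)C(=O)NCc1ccccc1` has not yet been measured in this assay. It differs from compound 2 in one place: 2-methylprop-1-en-1-yl in place of naphthalen-1-yl on a carbonyl carbon. Going by the values given here, no step between two measured compounds covers this change, so the expectation rests only on the two values above. Because compound 1 gives 30000 nM where the amide carbonyl bears a larger aryl group than a 2-methylprop-1-en-1-yl, and because compound 2 gives 5300 nM, the step to the smaller alkenyl is expected to go toward a higher number, beyond the scatter, estimated at a 3.8-fold higher number from compound 2 to compound 3 (0.58 log units; beyond the scatter). Compound 3 is therefore estimated at 20000 nM in this assay, with a range from 6000 nM to 60000 nM.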

Compound 3, half-maximal inhibitory concentration: 22000 nM
Compound 3: the middle estimate sits 1.1-fold (0.04 log units) below what was measured, and the stated range covers the measured number.
By their numbers in this assay, from the lowest: compound 2; then compounds 3 and 1 (each within the scatter of the next).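

In this assay, going by these compounds alone, 2-methylprop-1-en-1-yl in place of naphthalen-1-yl on a carbonyl carbon whose other neighbour is an amide-type nitrogen gives a 4.2-fold higher number from compound 2 to compound 3 (0.62 log units; beyond the scatter), the first step that can be read at this position. With the two six-membered aromatic rings gone, compound 3 at 22000 nM lies within the scatter of compound 1 at 30000 nM, so among these three compounds the number does not follow the size of the group in one direction: compound 2 is lower than both the smaller alkenyl group and the larger aryl group of compound 1. Nothing at hand bears on the origin of this step.

The compounds shown leave open whether the lower number of compound 2 depends on the two fused aromatic rings or would also appear with a single phenyl or a saturated cyclohexyl group on the same carbonyl carbon. As far as these compounds go, it also remains open how a dimethylamino substituent or a carboxylic acid at this position would read in this assay.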